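The compounds below may be only part of what the source reports. "The series", "measured", "known", "first", "only" and "open" are said of these compounds alone.

Measured in an ADME assay on S9 fraction from liver (Rattus norvegicus) for metabolic stability, read by LC-MS, using NADPH, with a stated time of 30 min; on this read-out lower numbers stand for a less stable compound and higher numbers for a more stable compound:
Compound 1 `CCCCCCCCc1ccc(OCC(=O)Cn2nnc(C)n2)cc1`: < 5%, a limit of the assay and not a number
Compound 2 `CCCCCCCCc1ccc(OCC(=O)Cn2nnc(C(=O)O)n2)cc1`: 52%

Going by the values given here, compound 2, at 52%, holds the only actual number in this assay. Compound 3 `CCCCCCCCc1ccc(OCC(=O)Cn2nnnc2C)cc1` brings (5-methyl-1H-tetrazol-1-yl in place of 5-carboxy-2H-tetrazol-2-yl on a saturated chain carbon bound to a carbonyl carbon), with 5-methyl-1H-tetrazol-1-yl in place of 5-carboxy-2H-tetrazol-2-yl on a saturated chain carbon bound to a carbonyl carbon. Among the compounds with values here, one measured step bears on this: a number at least 47 percentage points higher from compound 1 to compound 2 (beyond the scatter), large and beyond the scatter. Within the data shown here, no measured compound carries the 5-methyl-1H-tetrazol-1-yl group. Read in reverse, that step leads one to expect a large fall in this assay. The expected change is a number 47 percentage points lower from compound 2 to compound 3 (beyond the scatter). For compound 3 the estimated value is 5%, within a range of 2% to 22%.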

Compound 3, percent of the compound remaining: 32%
Estimate against measurement, compound 3: 27 percentage points below, and the stated range ends below it.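

In this assay, the attachment of the methyl tetrazole matters at this position, a saturated chain carbon bound to a carbonyl carbon: 5-methyl-1H-tetrazol-1-yl in place of 5-methyl-2H-tetrazol-2-yl gives a number at least 27 percentage points higher from compound 1 to compound 3 (beyond the scatter). A carboxy group is therefore not needed for a clear rise, although replacing 5-carboxy-2H-tetrazol-2-yl with 5-methyl-1H-tetrazol-1-yl still gives a number 20 percentage points lower from compound 2 to compound 3 (beyond the scatter). The full size of the rise cannot be read, as compound 1 stands at a limit of the assay: the limit of < 5% in this assay, at which 1 of the 3 values shown sits.

As far as these compounds go, it remains open how a carboxylic acid on the 1H-tetrazol-1-yl ring would read here. From the compounds shown here alone, the effect of an amine in place of the methyl group is also open.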